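Arylpiperazine series: nitro for fluoro and inhibition in the whole organism

A few compounds are considered here, and "the series" means these few. Any claim that something is new, unique, unknown or untested is made for them only; others in the source may bear on it.

Measured compounds:
compound 1 `CCC(=O)c1c(C)nn(CCCN2CCN(c3ccc(C)cc3)CC2)c(=O)c1N` — 9%
compound 2 `Cc1c(C#N)c(-c2ccccc2)nn1CCCN1CCN(c2ccc(F)cc2)CC1` — 9%

In a functional assay on the whole organism (Abdomen, strain Swiss) for inhibition, with Mus musculus as the target, with stated times of 30 min, 10 min and 5 min, at a dose of 10 mg/kg by the oral route (on this read-out lower numbers stand for a weaker effect and higher numbers for a stronger effect at the one dose given), compound 1 gives 9%, and in the same read-out compound 2 gives 9%. Compound 2 therefore stands level with compound 1 at the digits shown; the two values lie within the scatter of each other, and both are low on this read-out.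

Compound 3 `Cc1c(C#N)c(-c2ccccc2)nn1CCCN1CCN(c2ccc([N+](=O)[O-])cc2)CC1` arises from compound 2 by a single change on the aryl group of the piperazine:

nitro in place of fluoro on an aromatic carbon

The change, cut one bond further out, reads 4-fluorophenyl to 4-nitrophenyl, at the aromatic carbon para to a large group.

For the measured compounds named here, no step between measured compounds is available to guide the size of this change in this assay. With compound 2 at 9%, the step from compound 2 to compound 3 is expected to be small, a number 3 percentage points higher from compound 2 to compound 3 (within the scatter), not clearly beyond the scatter, with no firm direction. Compound 3 is estimated at 12%, range 0% to 30%.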

Compound 3, a percentage reported as inhibition, in the whole organism at one dose (the size of the read-out at that dose, not a potency): 0%
For compound 3 the middle estimate is 12 percentage points above the measured one; low and high end bracket the measured number.
By their numbers in this assay, from the lowest: compounds 3, 1 and 2 (each within the scatter of the next).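

In this assay, the change from 4-fluorophenyl to 4-nitrophenyl gives a number 9 percentage points lower from compound 2 to compound 3 (within the scatter). For the compounds shown here, this is the first comparison that isolates one place, and at this aromatic carbon, nitro in place of fluoro does not move the read-out beyond the scatter, leaving both compound 2 and compound 3 low. No measurement at hand bears on the reason for this result.

From the compounds shown here alone, it remains open whether an amine or a carboxylic acid on this aromatic carbon would lift the read-out clear of the scatter. Also open, going by these compounds, is whether a longer chain to the piperazine of compound 2 would change the level in this assay.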